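A few compounds are considered here, and "the series" means these few. Any claim that something is new, unique, unknown or untested is made for them only; others in the source may bear on it.

Compound 1 `COc1ccc(Cl)cc1S(=O)(=O)Nc1ccc(-c2nc3ccccc3o2)cc1` gives > 63000 nM in an assay on isolated protein for inhibition of malate dehydrogenase, mitochondrial (Sus scrofa), with stated times of 45 min and 30 min (a higher number here means a weaker inhibitor, a lower number a stronger inhibitor), and that figure is a limit of the assay rather than a measured number.
Compound 2 `O=S(=O)(Nc1ccc(-c2nc3ccccc3o2)cc1)c1ccc(Cl)c(C(F)(F)F)c1` gives > 63000 nM in this assay, again a limit.
Compound 3 `O=S(=O)(Nc1ccc(-c2nc3ccccc3o2)cc1)c1ccccc1Cl` gives > 63000 nM in this assay, also a limit.

Compound 3 therefore stands nowhere in particular on the numbers shown: all three measured compounds sit at the same point, (the limit of > 63000 nM in this assay, at which 3 of the 3 values shown sit), and none of them gives a genuine number. Among the measured compounds shown here, the only measured step that changes the group on the sulfonyl sulfur is a step that the two limits leave unreadable from compound 1 to compound 3. Both ends of that step are limits, and its size cannot be read.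

Compound 4 `O=S(=O)(Nc1ccc(-c2nc3ccccc3o2)cc1)c1ccc(Cl)c(Cl)c1` is not yet measured. It differs from compound 3 by 3,4-dichlorophenyl in place of 2-chlorophenyl on a sulfonyl sulfur. For the measured compounds named here, this change has no direct counterpart among the measured steps; the nearest is the step from compound 1 to compound 3, which exchanged one aryl group for another on the same sulfonyl sulfur without producing a readable change. Since every measured compound rests at the limit, there is no basis for expecting a step beyond the scatter in either direction in this assay.

Compound 4 is accordingly expected to land at about 100000 nM, with a range from 30000 nM to 400000 nM, and most probably to be reported again only as a limit. The expected step is a step that the limit leaves unreadable from compound 3 to compound 4.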

Compound 4, half-maximal inhibitory concentration: > 63000 nM
Compound 4 ended at the assay's limit; the forecaster's own chance of this, stated with the estimate: 85%; the middle value does not contradict the limit.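

Compound 4 also comes out as a limit rather than a number, so its steps from compound 1, compound 2 and compound 3 cannot be read. All four compounds sit at one point: (the limit of > 63000 nM in this assay, at which 4 of the 4 values shown sit). They leave open whether, in this assay, any group on the sulfonyl sulfur gives a genuine measured value.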